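The source may report more compounds than this note shows. Statements on the series, on what has been measured and on what is new or still open speak of the compounds shown alone.

Compound 3 `CC1CCN(C(=O)[C@@H]2C[C@H](S(=O)(=O)c3ccccc3)C[C@H]2C(=O)NC2(C#N)CC2)CC1` gives 0.5 nM in an assay on isolated protein for inhibition of cathepsin S (Homo sapiens), read by fluorescence, with a stated time of 20 min; a higher number here means a weaker inhibitor, a lower number a stronger inhibitor. Among the three measured compounds it sits at the potent end together with compound 2 `N#CC1(NC(=O)[C@@H]2C[C@@H](S(=O)(=O)c3ccccc3)C[C@H]2C(=O)N2CC3CCC(C2)O3)CC1`, which gives 1 nM; the two lie within the scatter of each other. Compound 1 `N#CCNC(=O)[C@@H]1C[C@@H](S(=O)(=O)CC2CC2)C[C@H]1C(=O)N1CCOCC1` gives 230 nM and stands far above both, a gap well beyond the scatter.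

Compound 4 `N#CC1(NC(=O)[C@@H]2C[C@@H](S(=O)(=O)c3ccccc3)C[C@H]2C(=O)N2CCS(=O)(=O)CC2)CC1` differs from compound 3 in one place: 1,1-dioxothiomorpholin-4-yl in place of 4-methylpiperidin-1-yl on a carbonyl carbon. Within the data shown here, one measured step bears on this position, the exchange at the same carbonyl carbon that gave a 2.0-fold lower number from compound 2 to compound 3 (0.30 log units; within the scatter), a shift that stayed within the scatter. Among the measured compounds shown here, nothing measured here separates a ring bearing two hetero atoms from one bearing one at this carbon, so the prior step is the only guide.

Compound 4 is therefore expected to stay close to compound 3, with a step of a 1.8-fold higher number from compound 3 to compound 4 (0.26 log units; within the scatter) that is not expected to exceed the scatter. Compound 4 is estimated at 0.9 nM in this assay, with a range from 0.3 nM to 3 nM.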

Compound 4, half-maximal inhibitory concentration: 4 nM
Estimate against measurement, compound 4: 4.4-fold (0.65 log units) below, and the stated range ends below it.
By their numbers in this assay, from the lowest: compounds 3 and 2 (each within the scatter of the next); then compound 4; then compound 1.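

At this carbonyl carbon the rings are not interchangeable: in this assay 1,1-dioxothiomorpholin-4-yl gives an 8.0-fold higher number from compound 3 to compound 4 (0.90 log units; beyond the scatter) and a 4.0-fold higher number from compound 2 to compound 4 (0.60 log units; beyond the scatter), both beyond the scatter, whereas the earlier exchange at the same carbon, a 2.0-fold lower number from compound 2 to compound 3 (0.30 log units; within the scatter), stayed within it. The position therefore tells these groups apart, although both new steps are modest and compound 4 still gives 4 nM. No measured evidence bears on what lies behind this shift.

Open, going by these compounds, is whether the shift follows the ring sulfur or the two oxygens on it: plain thiomorpholin-4-yl at this carbonyl carbon would separate the two. Equally open, on these data alone, is how a ring carrying a free amine, such as piperazin-1-yl, would read here.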